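The source may report more compounds than this note shows. Statements on the series, on what has been measured and on what is new or still open speak of the compounds shown alone.

Two compounds have been measured so far in a functional assay on MCF7 cells (Homo sapiens) for cytotoxicity, read by MTT assay, with a stated time of 72 h; on this read-out lower numbers stand for stronger inhibition and higher numbers for weaker inhibition:

- compound 1 `CCC[S+]([O-])CCCCN=C=S` gives 5960 nM
- compound 2 `[O-][S+](CCCCN=C=S)Cc1cccs1` gives 4140 nM

Within the data shown here, compound 2 therefore stands level with compound 1, the only other measured compound, as the two values lie within the scatter of each other. The next compound, compound 3 `[O-][S+](CCCCN=C=S)Cc1ccco1`, carries furan-2-yl in place of thiophen-2-yl on a saturated chain carbon bound to a sulfur. Among the measured compounds shown here, no measured step compares these two rings directly. For the measured compounds named here, the one step that bears on the change is at the same place, where thiophen-2-yl replaced ethyl: a 1.4-fold lower number from compound 1 to compound 2 (0.16 log units; within the scatter). That replacement stayed within the scatter in this assay, and the exchange of one ring for another is not expected to do more, so no step beyond the scatter is expected and no direction can be favoured. The expected change is a 1.2-fold higher number from compound 2 to compound 3 (0.06 log units; within the scatter). Compound 3 is estimated at 4800 nM, with an expected range from 2400 nM to 9000 nM.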

Compound 3, half-maximal inhibitory concentration: 5680 nM
Compound 3: middle estimate off by 1.2-fold (0.07 log units), on the low side; measured number inside the range.
By their numbers in this assay, from the lowest: compounds 2, 3 and 1 (each within the scatter of the next).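

In this assay, among these compounds, the first direct comparison of the two rings on a saturated chain carbon bound to a sulfur gives a 1.4-fold higher number from compound 2 to compound 3 (0.14 log units; within the scatter) and so does not separate thiophen-2-yl from furan-2-yl, although one ring holds a sulfur and the other an oxygen. Set against ethyl at the same place, furan-2-yl gives a 1.0-fold lower number from compound 1 to compound 3 (0.02 log units; within the scatter) as well, so that ethyl, thiophen-2-yl and furan-2-yl now stand level in this assay, and neither five-membered aromatic ring has been told apart from ethyl, a finding that holds for these three compounds only. No available evidence bears on why these groups read alike, so the result comes without an explanation.

The compounds shown leave open whether any group at this place can move the number beyond the scatter, as an amine, a carboxylic acid, a phenyl ring or a longer chain might or might not do. They also leave open whether a change elsewhere on the shared core would matter more than these exchanges have done.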